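Swapping the Carboxyethyl Group of Compound 2 for Hydroxymethylethyl

This account rests on a few compounds, and the source may have more. Where it says the series, first, only, none or still open, it means among the compounds named here.

In a functional assay on MCF7 cells (Homo sapiens) for antiproliferative activity, read by MTT assay, with a stated time of 72 h (a lower number here means a stronger inhibitor, a higher number a weaker inhibitor), compound 1 (`CCn1cc(C(CC)(CC)c2ccc(C#CC(O)(CC)CC)c(C)c2)cc1C(=O)OCCO`) gives 1880 nM and compound 2 (`CCn1cc(C(CC)(CC)c2ccc(C#CC(O)(CC)CC)c(C)c2)cc1C(=O)NCCC(=O)O`) gives 30600 nM as the higher of the two numbers. Among the measured compounds shown here, the only measured step is a 16-fold higher number from compound 1 to compound 2 (1.21 log units; beyond the scatter) and it places (2-carboxyethyl)amino where 2-hydroxyethoxy stood on a carbonyl carbon. Compound 3 (`CCn1cc(C(CC)(CC)c2ccc(C#CC(O)(CC)CC)c(C)c2)cc1C(=O)N[C@@H](C)CO`) departs from compound 2 by one change (1-(hydroxymethyl)ethyl in place of 2-carboxyethyl on an amide-type nitrogen) on an amide-type nitrogen, with 1-(hydroxymethyl)ethyl in place of 2-carboxyethyl. Compound 3 thus loses the 2-carboxyethyl group but keeps the amide-type nitrogen, so it only partly returns toward compound 1. For the measured compounds named here, the large size of a 16-fold higher number from compound 1 to compound 2 (1.21 log units; beyond the scatter) is the sole guide, and it points to a sizeable fall, perhaps not a complete one. The expected step is an 8.7-fold lower number from compound 2 to compound 3 (0.94 log units; beyond the scatter) and it runs toward a lower number. In this assay the estimate for compound 3 is 3500 nM with an expected range of 1200 nM to 11000 nM around it.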

Compound 3, half-maximal inhibitory concentration: 1910 nM
Compound 3: the middle estimate sits 1.8-fold (0.26 log units) above what was measured; measured number inside the range.
By their numbers in this assay, from the lowest: compounds 1 and 3 (each within the scatter of the next); then compound 2.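

In this assay, placing 1-(hydroxymethyl)ethyl where 2-carboxyethyl stood on the amide-type nitrogen gives a 16-fold lower number from compound 2 to compound 3 (1.20 log units; beyond the scatter) and so shows that the high number of compound 2 does not come with the amide-type nitrogen as such. The step of a 1.0-fold higher number from compound 1 to compound 3 (0.01 log units; within the scatter) puts (1-(hydroxymethyl)ethyl)amino and 2-hydroxyethoxy on the carbonyl carbon level with each other, so the earlier jump in number goes with the 2-carboxyethyl group among the compounds shown, not with the swap of ester for amide. Nothing available explains why the number moves in this way.

The compounds shown leave open where a methyl ester of the 2-carboxyethyl group, a terminal amine or a longer hydroxyalkyl chain on the same nitrogen would fall. They also leave open what the opposite configuration of the 1-(hydroxymethyl)ethyl stereocentre would give.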